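From 4-fluorophenyl to 4-chlorophenyl: compound 3 to compound 4

The source may hold more compounds than are shown below. What is called first, only, known or untested is meant among the compounds shown, and "the series" means these compounds.

Measured in an ADME assay on MT4 cells (Homo sapiens) for cytotoxicity, read by MTT assay, with a stated time of 96 h; on this read-out higher numbers stand for lower toxicity in this test and lower numbers for higher toxicity in this test:
Compound 1 `NS(=O)(=O)c1ccc(N2N=C(c3ccc(Oc4ccccc4)cc3)CC2c2ccccc2)cc1`: 42000 nM
Compound 2 `NS(=O)(=O)c1ccc(N2N=C(c3ccc(Oc4ccccc4)cc3)CC2c2cccc(Cl)c2)cc1`: 8000 nM
Compound 3 `NS(=O)(=O)c1ccc(N2N=C(c3ccc(Oc4ccccc4)cc3)CC2c2ccc(F)cc2)cc1`: 33000 nM

Two steps place compound 3 among the measured compounds: a 1.3-fold lower number from compound 1 to compound 3 (0.10 log units; within the scatter), and a 4.1-fold higher number from compound 2 to compound 3 (0.62 log units; beyond the scatter). Compound 4 `NS(=O)(=O)c1ccc(N2N=C(c3ccc(Oc4ccccc4)cc3)CC2c2ccc(Cl)cc2)cc1` differs from compound 3 in one place: chloro in place of fluoro on an aromatic carbon, para to a large group. The closest guide is compound 2, with a 5.3-fold lower number from compound 1 to compound 2 (0.72 log units; beyond the scatter), though its chloro sits in a 3-chlorophenyl group rather than a 4-chlorophenyl group. The fluoro step above shows that fluoro gives no clear change from hydrogen, so a modest move to a lower number is expected, possibly close to the scatter. The step expected is a 2.1-fold lower number from compound 3 to compound 4 (0.31 log units; beyond the scatter). The estimate for compound 4 is 16000 nM, with an expected range of 6000 nM to 38000 nM.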

Compound 4, half-maximal cytotoxic concentration: 9000 nM
The estimate for compound 4 lay 1.8-fold (0.25 log units) above the measured number; the measured number falls inside the stated range.
By their numbers in this assay, from the lowest: compounds 2 and 4 (each within the scatter of the next); then compounds 3 and 1 (each within the scatter of the next).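

In this assay, among the compounds shown here, chloro in place of fluoro on this aromatic carbon gives a 3.7-fold lower number from compound 3 to compound 4 (0.56 log units; beyond the scatter) and chloro in place of hydrogen gives a 4.7-fold lower number from compound 1 to compound 4 (0.67 log units; beyond the scatter), so the para position also responds to chloro, which the earlier compounds showed only for the 3-chlorophenyl group. Moving chloro between these two placements gives a 1.1-fold higher number from compound 2 to compound 4 (0.05 log units; within the scatter) and so separates neither placement from the other. Nothing available explains these shifts. On these data alone, whether a bromo or a methoxy on the same carbon would follow chloro or fluoro remains open.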